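A few compounds are considered here, and "the series" means these few. Any claim that something is new, unique, unknown or untested is made for them only; others in the source may bear on it.

Values in an ADME assay on the whole organism (plasma) for pharmacokinetics, with Rattus norvegicus as the target, with a stated time of 6 h, at a dose of 10 mg/kg by the oral route; a lower number here means less compound in the circulation, a higher number more compound in the circulation at the dose given:
- compound 1 `O=c1c(OC2CCCC2)c(N2CCN(S(=O)(=O)Cc3ccncc3)CC2)cnn1-c1cc(F)cc(F)c1`: 20 ng.h/mL
- compound 2 `CC1(COc2c(N3CCN(S(=O)(=O)Cc4cccc(N)c4)CC3)cnn(-c3cccc(Cl)c3)c2=O)CC1`: 5700 ng.h/mL
- compound 3 `CC1(COc2c(N3CCN(S(=O)(=O)Cc4ccc(N)c(C(F)(F)F)c4)CC3)cnn(-c3cccc(Cl)c3)c2=O)CC1`: 640 ng.h/mL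

Compound 3 is second highest of the three, with compound 2 above it and compound 1 far below it. Compound 4 `CCc1cc(CS(=O)(=O)N2CCN(c3cnn(-c4cccc(Cl)c4)c(=O)c3OCC3(C)CC3)CC2)ccc1N` carries ethyl in place of trifluoromethyl on an aromatic carbon, ortho to an amino group: ethyl in place of trifluoromethyl on an aromatic carbon.

Within the data shown here, only one measured step touches this ring: an 8.9-fold lower number from compound 2 to compound 3 (0.95 log units; beyond the scatter). Among the measured compounds shown here, that step also brings in the trifluoromethyl group, but it changes the ring in more than one way, and no measured pair isolates ethyl against trifluoromethyl. The expected step is therefore upward and smaller: a 1.9-fold higher number from compound 3 to compound 4 (0.27 log units; within the scatter). For compound 4 the estimate is 1200 ng.h/mL, with an expected range of 300 ng.h/mL to 4000 ng.h/mL.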

Compound 4, area under the concentration-time curve: 9400 ng.h/mL
Estimate against measurement, compound 4: 7.8-fold (0.89 log units) below; measured number outside the range, above it.
By their numbers in this assay, from the lowest: compound 1; then compound 3; then compounds 2 and 4 (each within the scatter of the next).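

With the amino group and the rest of the molecule held constant, the group on this aromatic carbon, ortho to an amino group, matters greatly in this assay: ethyl in place of trifluoromethyl gives a 15-fold higher number from compound 3 to compound 4 (1.17 log units; beyond the scatter) in the area under the curve. The second comparison, a 1.6-fold higher number from compound 2 to compound 4 (0.22 log units; within the scatter) and within the scatter, places the ethyl compound level with the 3-aminophenyl compound, although that step alters the ring in more than one way. No measured evidence accounts for either step.
As far as these compounds go, whether methyl or a longer chain such as propyl on this carbon would give a number like that of ethyl remains open.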